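This account rests on a few compounds, and the source may have more. Where it says the series, first, only, none or still open, it means among the compounds named here.

Compound 1 `Cc1ccc(C2=Nn3c(nnc3C(C)c3ccc(CC(C)C)cc3)SC2)cc1` – 5000 nM
Compound 2 `CC(c1ccc(-c2ccccc2)c(F)c1)c1nnc2n1N=C(c1ccc(Br)cc1)CS2` – 5000 nM

In a functional assay on Huh-7 cells (Homo sapiens) for inhibition, read by sulforhodamine B assay, with a stated time of 72 h (on this read-out higher numbers stand for weaker inhibition and lower numbers for stronger inhibition), compound 1 stands level with compound 2, as their two values match at the digits shown. Going by the values given here, with only these two measurements, compound 1 sits at the one level seen so far, and no measured pair differs in a single place. Nothing here therefore shows directly what a single change does.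

Compound 3 `CC(C)Cc1ccc(C(C)c2nnc3n2N=C(c2ccc(OC(F)(F)F)cc2)CS3)cc1` is compound 1 with one change: trifluoromethoxy in place of methyl on an aromatic carbon, para to a large group (trifluoromethoxy in place of methyl on an aromatic carbon). The change is larger than a swap of like for like, but the data give no direction for it. In this assay, no step beyond the scatter is therefore expected. The estimated change is a 1.3-fold lower number from compound 1 to compound 3 (0.10 log units; within the scatter). For compound 3, the expected value is 4000 nM, with an estimated range of 1500 nM to 10000 nM.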

Compound 3, half-maximal inhibitory concentration: 3600 nM
Compound 3: the middle estimate sits 1.1-fold (0.05 log units) above what was measured, and the stated range covers the measured number.
By their numbers in this assay, from the lowest: compounds 3, 1 and 2 (each within the scatter of the next).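

Placing trifluoromethoxy in place of methyl on an aromatic carbon, para to a large group, gives a 1.4-fold lower number from compound 1 to compound 3 (0.14 log units; within the scatter) in this assay. Going by these compounds alone, this is the first direct reading of a single change, and it shows that this position can take a group of five heavy atoms instead of one, with one hydrogen-bond acceptor added, without a step beyond the scatter. No measurement available here speaks to the reason for this result.

Going by these compounds, it remains open whether any group at this position can move the number beyond the scatter, and how an amine or a carboxylic acid on this aromatic carbon would read. On these data alone, it is also open whether the same swap would give a similar step if another part of compound 1 were changed.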